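A Larger Substituent in Place of Hydrogen on Compound 1

This account rests on a few compounds, and the source may have more. Where it says the series, first, only, none or still open, it means among the compounds named here.

Compound 1 `CCCCc1cccc(=O)n1Cc1ccc(-c2ccccc2-c2nn[nH]n2)cc1` has been tested in a functional assay (aorta) for antagonist activity, with Oryctolagus cuniculus as the target (on this read-out higher numbers stand for weaker inhibition and lower numbers for stronger inhibition), where compound 1 gives 4 nM. Among the two numbers so far, this is the highest; the only other measured compound is compound 2 `CCCCc1ccc(CNS(C)(=O)=O)c(=O)n1Cc1ccc(-c2ccccc2-c2nn[nH]n2)cc1`, and in this assay compound 2 gives 2 nM. The step between them, a 2.0-fold lower number from compound 1 to compound 2 (0.30 log units; within the scatter), arises from (methanesulfonamido)methyl in place of hydrogen on an aromatic carbon and stays within the scatter.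

Compound 3 `CCCCc1ccc(CNC(=O)Nc2ccccc2)c(=O)n1Cc1ccc(-c2ccccc2-c2nn[nH]n2)cc1` has not been measured. It differs from compound 1 by ((phenylcarbamoyl)amino)methyl in place of hydrogen on an aromatic carbon. For the measured compounds named here, the single step that bears on this change is a 2.0-fold lower number from compound 1 to compound 2 (0.30 log units; within the scatter), in which a group entered at the same aromatic carbon; that step was small. Going by the values given here, with only this one step to go on, no movement beyond the scatter is expected in this assay for compound 3, though the sign of the one known step points slightly toward a lower number. Compound 3 is therefore expected to give about 3 nM, with a range from 1 nM to 10 nM. This estimate means an expected step of a 1.3-fold lower number from compound 1 to compound 3 (0.12 log units; within the scatter), which lies within the scatter.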

Compound 3, half-maximal inhibitory concentration: 30 nM
The estimate for compound 3 lay 10-fold (1.00 log units) below the measured number, and the stated range ends below it.
By their numbers in this assay, from the lowest: compounds 2 and 1 (each within the scatter of the next); then compound 3.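

In this assay, the aromatic carbon two atoms from the ring nitrogen proves not to be indifferent to what enters there: ((phenylcarbamoyl)amino)methyl in place of hydrogen gives a 7.5-fold higher number from compound 1 to compound 3 (0.88 log units; beyond the scatter) while the earlier substituent at this carbon stayed within the scatter. For the compounds shown here, compound 2 and compound 3 share the methyl carbon and the amine nitrogen, so the difference between them lies in what that nitrogen carries, and phenylcarbamoyl in place of methylsulfonyl gives a 15-fold higher number from compound 2 to compound 3 (1.18 log units; beyond the scatter) which is a larger step than the one from the unsubstituted compound. No measured information bearing on this result is available to explain it.

The compounds shown do not separate the contribution of the terminal phenyl ring from that of the carbonyl linkage, so it remains open whether a methylurea, an acetamide or a free amine on the same methyl carbon would stay close to compound 2 or fall nearer to compound 3. A benzenesulfonamide, which would keep the sulfonyl group and add the phenyl ring, would bear on the same question.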